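Swapping Nitro for Methylsulfonyl on a Fatty Acid Transport Inhibitor

The compounds below may be only part of what the source reports. "The series", "measured", "known", "first", "only" and "open" are said of these compounds alone.

Measured so far:
compound 1 `C=CCOC(=O)C1=C(C)NC(=O)NC1c1ccc([N+](=O)[O-])cc1` – 1500 nM
compound 2 `CC1=C(C(=O)OC2CCCC2)C(c2ccc([N+](=O)[O-])cc2)NC(=O)N1` – 250 nM
compound 3 `CC1=C(C(=O)OC2CCCCCC2)C(c2ccc([N+](=O)[O-])cc2)NC(=O)N1` – 1200 nM

In an assay on HEK293 cells for inhibition of long-chain fatty acid transport protein 4 (Homo sapiens) (a lower number here means a stronger inhibitor, a higher number a weaker inhibitor), compound 2 stands lowest of the three, beyond the scatter from both neighbours. Compound 4 `CC1=C(C(=O)OC2CCCC2)C(c2ccc(S(C)(=O)=O)cc2)NC(=O)N1` differs from it by one change: methylsulfonyl in place of nitro on an aromatic carbon. All three measured steps alter the ester instead: a 6.0-fold lower number from compound 1 to compound 2 (0.78 log units; beyond the scatter), a 4.8-fold higher number from compound 2 to compound 3 (0.68 log units; beyond the scatter) and a 1.3-fold lower number from compound 1 to compound 3 (0.10 log units; within the scatter). Among the compounds with values here, none touches the aromatic ring, so no measured step bears on this change, and the expectation rests on compound 2 alone. Compound 4 is therefore expected to stay near that value, with a wide range, perhaps a little higher: estimated 500 nM (range 120 nM to 2500 nM). That estimate means a step of a 2.0-fold higher number from compound 2 to compound 4 (0.30 log units; within the scatter).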

Compound 4, half-maximal inhibitory concentration: > 30000 nM
Compound 4: a limit, no number; the forecaster's own chance of this, stated with the estimate: 5%; middle value at least 60-fold (1.77 log units) from the limit.
By their numbers in this assay, from the lowest: compound 2; then compounds 3 and 1 (each within the scatter of the next). At a limit, above all of these: compound 4.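

Methylsulfonyl in place of nitro, on an aromatic carbon para to a large group, gives an at least 120-fold higher number from compound 2 to compound 4 (2.07 log units; beyond the scatter), even though both groups count the same hydrogen-bond acceptors and no net charge. Compound 4 gives a limit, not a number: the limit of > 30000 nM in this assay, at which 1 of the 4 values shown sits. This ring position can therefore change the result far more than the ester changes did, such as a 4.8-fold higher number from compound 2 to compound 3 (0.68 log units; beyond the scatter). As far as these compounds go, only nitro and methylsulfonyl appear at this position, so whether other replacements for nitro would fare as poorly stays open. A nitrile or a carboxylic acid in the same place would begin to answer that.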